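A few compounds are considered here, and "the series" means these few. Any claim that something is new, unique, unknown or untested is made for them only; others in the source may bear on it.

The measured compounds:
compound 1, `COc1ccccc1N1C(=O)C(C)SC1c1cccc(C(=O)NCCCCc2ccccc2)c1`, 45.1 nM
compound 2, `CC(C)(C)c1conc1N1C(=O)CSC1c1cccc(C(=O)NCCCCc2ccccc2)c1`, > 1000 nM
compound 3, `CCOC(=O)c1sc(N2C(=O)CSC2c2cccc(C(=O)NCCCCn3cccn3)c2)nc1C`, 430 nM

All three were tested in a functional assay on HOS-TE85 cells (Homo sapiens) for inhibition, read by CCK-8 assay, with a stated time of 72 h; a higher number here means a weaker inhibitor, a lower number a stronger inhibitor. In this assay compound 1 gives 45.1 nM and compound 3 gives 430 nM. Compound 2 stands apart: its result of > 1000 nM is a limit of the assay and not a number. That limit is the limit of > 1000 nM in this assay, at which 1 of the 3 values shown sits. Compound 2 therefore sits at the weak end of what has been measured, with only a bound and no point value, so any step away from it can be bounded on one side only.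

Compound 4, `CCN1C(=O)CSC1c1cccc(C(=O)NCCCCc2ccccc2)c1`, has not yet been measured in this assay. Set against compound 2, the change is a group of 2 heavy atoms (2 carbon; no ring) in place of a group of 9 heavy atoms (7 carbon, 1 nitrogen, 1 oxygen; one five-membered aromatic ring with 2 hetero atoms), on an amide-type nitrogen in a ring. Within the data shown here, no pair of measured compounds shares this change, so the account rests on compound 2 alone, and compound 2 gives no number, only a limit. Among the measured compounds shown here, a small group on that ring nitrogen has no precedent; the two compounds with a number carry a ring there. The step from compound 2 to compound 4 is expected to be a step that the limit leaves unreadable from compound 2 to compound 4, and it may well fall within the scatter or end again at the limit. Compound 4 is estimated at 1500 nM in this assay, with a range from 300 nM to 8000 nM.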

Compound 4, half-maximal inhibitory concentration: > 1000 nM
Compound 4: only a limit was reported; the forecaster's own chance of this, stated with the estimate: 55%; the middle value does not contradict the limit.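

Compound 2 and compound 4 both end at a limit of the assay and not at a number in this assay, and no step between them can be read: the limit of > 1000 nM in this assay, at which 2 of the 4 values shown sit.

The compounds shown leave open how the ethyl of compound 4 and the larger ring-bearing group of compound 2 compare on the amide-type nitrogen, with no point value for either.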